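The source may report more compounds than this note shows. Statements on the series, on what has been measured and on what is new or still open speak of the compounds shown alone.

Measured so far:
compound 1 `O=C(CCN1CCN(c2ccnc3cc(Cl)ccc23)CC1)N/N=C/c1ccccc1` — 300 nM
compound 2 `O=C(CCN1CCN(c2ccnc3cc(Cl)ccc23)CC1)N/N=C/c1ccc([N+](=O)[O-])cc1` — 12100 nM

In an ADME assay on cells (Splenocyte, Mus musculus, strain BALB/c) for cytotoxicity, read by thymidine incorporation, with a stated time of 24 h (a higher number here means a weaker inhibitor, a lower number a stronger inhibitor), compound 2 gives 12100 nM, the higher of the two numbers measured. Going by the values given here, its only neighbour is compound 1, which in this assay gives 300 nM. Among the compounds with values here, the single measured step between them is a 40-fold higher number from compound 1 to compound 2 (1.61 log units; beyond the scatter), a large rise that lies beyond the scatter.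

Compound 3 `O=C(CCN1CCN(c2ccnc3cc(Cl)ccc23)CC1)N/N=C/c1ccccc1O` differs from compound 2 by 2-hydroxyphenyl in place of 4-nitrophenyl on a carbon with a double bond to nitrogen. The change removes the very group whose arrival produced a 40-fold higher number from compound 1 to compound 2 (1.61 log units; beyond the scatter), so that part of the step is expected to run backwards and carry the number down toward compound 1. The hydroxyl that enters has no measured counterpart among these compounds, so its share of the step is unknown, and the range must be kept wide. On balance a marked fall is expected. The expected step is a 12-fold lower number from compound 2 to compound 3 (1.08 log units; beyond the scatter). For compound 3 the estimate in this assay is 1000 nM, with a range from 200 nM to 8000 nM.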

Compound 3, half-maximal inhibitory concentration: 11500 nM
Estimate against measurement, compound 3: 12-fold (1.06 log units) below; the measured number lies above the stated range.
By their numbers in this assay, from the lowest: compound 1; then compounds 3 and 2 (each within the scatter of the next).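

In this assay, swapping 4-nitrophenyl for 2-hydroxyphenyl on the carbon with a double bond to nitrogen gives a 1.1-fold lower number from compound 2 to compound 3 (0.02 log units; within the scatter), so the two substituted compounds cannot be told apart, even though the groups differ in kind and in where they sit on the phenyl ring. The nitro group is therefore not required for the high number, since adding a hydroxyl to the phenyl ring gives a 38-fold higher number from compound 1 to compound 3 (1.58 log units; beyond the scatter), a large step of nearly the same size as the one seen with nitro. Among these three compounds the unsubstituted phenyl of compound 1 alone gives a low number, and nothing measured here explains why both substituents have this effect.

Each substituent appears at only one place on the ring, so the compounds shown do not separate the identity of a group from its location. As far as these compounds go, it also remains open whether a small group such as fluorine or methyl, or a methoxy group or an amine, would leave the number near that of compound 1 or raise it as far as nitro and hydroxy do.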